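This account rests on a few compounds, and the source may have more. Where it says the series, first, only, none or still open, it means among the compounds named here.

Going by the values given here, compound 1, `CC1(C)[C@@H]2CC[C@@]1(CS(=O)(=O)N1CCN(c3cc(C(F)(F)F)ccn3)CC1)C(=O)C2`, is the only compound with a numerical result: in a functional assay on CHO-K1 cells for antagonist activity at C-X-C chemokine receptor type 3 (Homo sapiens), read by FLIPR and calcium flux (a higher number here means a weaker inhibitor, a lower number a stronger inhibitor), compound 1 gives 25100 nM. Compound 2, `CC1(C)[C@@H]2CC[C@@]1(CS(=O)(=O)N1C[C@@H]3C[C@H]1CN3c1ccc(C(F)(F)F)cn1)C(=O)C2`, gives > 31600 nM in this assay, which is a limit and not a number (the limit of > 31600 nM in this assay, at which 1 of the 2 values shown sits). Compound 3, `CC1(C)[C@@H]2CC[C@@]1(CS(=O)(=O)N1CCN(c3ccc(C#N)cn3)CC1)C(=O)C2`, differs from compound 1 by one change: 5-cyanopyridin-2-yl in place of 4-(trifluoromethyl)pyridin-2-yl on an amine nitrogen in a ring. Among the compounds with values here, no measured pair shows this change, so no step in this assay is known for it, and a step no larger than the usual scatter, in either direction, is expected. Compound 3 is therefore estimated at 25000 nM in this assay, within 8000 nM to 80000 nM, an expected step of a 1.0-fold lower number from compound 1 to compound 3 (0.00 log units; within the scatter).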

Compound 3, half-maximal inhibitory concentration: > 31600 nM
Compound 3 gave a limit, no number (the forecaster's own chance of this, stated with the estimate: 40%); at least 1.2-fold (0.10 log units) between middle value and limit.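

Placing 5-cyanopyridin-2-yl on this amine nitrogen gives an at least 1.2-fold higher number from compound 1 to compound 3 (0.10 log units; that floor lies within the scatter), so this first change at the position brings no gain in inhibition. In this assay compound 3 gives only a limit, not a number, and compound 2 stands at the same limit: the limit of > 31600 nM in this assay, at which 2 of the 3 values shown sit.

On these data alone, how far compound 3 truly lies from compound 1 stays open. Also open, as far as these compounds go, is whether a pyridin-2-yl carrying an amine or a carboxylic acid in this place would give a clearly lower number.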